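Chloro for amino on the compound 3 scaffold

The source may hold more compounds than are shown below. What is called first, only, known or untested is meant among the compounds shown, and "the series" means these compounds.

Measured in an ADME assay on L1210/0 cells (Mus musculus) for cytotoxicity, with a stated time of 48 h; a lower number here means a stronger inhibitor, a higher number a weaker inhibitor:
- compound 1 `CC(=O)OC(C)Cn1cnc2c(Cl)nc(I)nc21`: 13000 nM
- compound 2 `Nc1ncnc2c1ncn2C1CC(O)C(/C=N/O)O1`: 17400 nM
- compound 3 `Nc1nc(N)c2ncn([C@H]3CCCC[C@H]3CO)c2n1`: > 200000 nM (a limit)

In this assay compound 3 gives > 200000 nM, which is a limit of the assay and not a number. The series therefore holds (the limit of > 200000 nM in this assay, at which 1 of the 3 values shown sits), and compound 3 has no exact place on the scale. Only compound 1 and compound 2 carry numbers.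

Compound 4 `Nc1nc(Cl)c2ncn([C@H]3CCCC[C@H]3CO)c2n1` has chloro in place of amino on an aromatic carbon. Among the compounds with values here, no measured pair isolates this change, so the expectation rests on thin ground. Compound 1 also holds a chloro on an aromatic carbon and gives 13000 nM, which supports a modest expectation of stronger inhibition in this assay for compound 4. Compound 1 differs from compound 4 in other places too, so a second limit remains a real possibility. The expected change is an at least 2.8-fold lower number from compound 3 to compound 4 (0.45 log units; beyond the scatter), and this size is only an estimate. For compound 4 the estimated value is 70000 nM, with an expected range from 20000 nM to 200000 nM.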

Compound 4, half-maximal inhibitory concentration: > 200000 nM
Compound 4 ended at the assay's limit; the forecaster's own chance of this, stated with the estimate: 35%; middle value at least 2.8-fold (0.45 log units) away from the limit.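

In this assay compound 4 gives > 200000 nM, which is a limit and not a number. Compound 3 also stands at a limit, so no step can be read between compound 3 and compound 4: the limit of > 200000 nM in this assay, at which 2 of the 4 values shown sit.

The compounds shown leave open whether chloro in place of amino on an aromatic carbon changes the read-out on this scaffold at all.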